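Swapping an aryl group on the shared core: compound 1 to compound 4

The compounds below may be only part of what the source reports. "The series", "measured", "known", "first", "only" and "open" are said of these compounds alone.

Measured compounds:
- compound 1, `CC(c1ccc(-c2ccccc2)c(F)c1)c1nnc2n1N=C(c1ccc(OC(F)(F)F)cc1)CS2`, 8400 nM
- compound 2, `COc1ccc2cc(C(C)c3nnc4n3N=C(c3ccc(OC(F)(F)F)cc3)CS4)ccc2c1`, 16000 nM
- compound 3, `CC(C)Cc1ccc(C(C)c2nnc3n2N=C(c2ccc(Cl)cc2)CS3)cc1`, 5700 nM

In a functional assay on Huh-7 cells (Homo sapiens) for inhibition, read by sulforhodamine B assay, with a stated time of 72 h (on this read-out lower numbers stand for stronger inhibition and higher numbers for weaker inhibition), compound 1 gives 8400 nM. Among the three numbers it stands second highest, yet its nearest neighbour, compound 3 at 5700 nM, and its furthest, compound 2 at 16000 nM, both lie within the usual scatter of it, so no order among the three can be read from these values.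

Compound 4, `CC(c1ccc(-c2ccccc2)c(F)c1)c1nnc2n1N=C(c1ccc(Cl)cc1Cl)CS2`, has not yet been measured. It differs from compound 1 in one place: 2,4-dichlorophenyl in place of 4-(trifluoromethoxy)phenyl on a carbon with a double bond to nitrogen. Going by the values given here, no pair of measured compounds isolates this change, and compound 3, which carries a chlorophenyl group on the same position, also differs from compound 1 elsewhere, so its number cannot be taken as a step. On that basis a step from compound 1 to compound 4 beyond the scatter is not expected in either direction. Compound 4 is therefore estimated at 7000 nM in this assay, with a range from 1800 nM to 28000 nM, which means an expected step of a 1.2-fold lower number from compound 1 to compound 4 (0.08 log units; within the scatter).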

Compound 4, half-maximal inhibitory concentration: 3700 nM
For compound 4 the middle estimate is 1.9-fold (0.28 log units) above the measured one; the range from low to high includes it.
By their numbers in this assay, from the lowest: compounds 4, 3, 1 and 2 (each within the scatter of the next, the first and the last beyond it).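

In this assay, the exchange at this position gave a 2.3-fold lower number from compound 1 to compound 4 (0.36 log units; beyond the scatter) when 2,4-dichlorophenyl replaced 4-(trifluoromethoxy)phenyl on a carbon with a double bond to nitrogen. The earlier compounds shown here each differed in more than one place and lay within the scatter of compound 1, so they could not show that this position alone can move the number. The step is modest, but it shows that the aryl group at this position matters on the shared core of compound 1.

No measurement at hand accounts for the step. Going by these compounds, whether the two chlorine atoms contribute together or singly remains open, as does how the position would respond to a phenyl ring bearing an amine or a carboxylic acid.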